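The compounds below may be only part of what the source reports. "The series", "measured", "known", "first", "only" and "open" are said of these compounds alone.

Compound 1 `N#C[Se]Cc1cccc([N+](=O)[O-])c1` gives 12200 nM 
Compound 2 `N#C[Se]Cc1ccc(Br)cc1` gives 12700 nM 

In an ADME assay on Jurkat cells (Homo sapiens) for cytotoxicity, read by trypan blue exclusion, with a stated time of 24 h (a lower number here means a stronger inhibitor, a higher number a weaker inhibitor), compound 2 at 12700 nM stands within the scatter of compound 1 at 12200 nM and no order can be drawn between them. Compound 3 `N#C[Se]Cc1ccc(C#N)cc1` is compound 2 with one change: cyano in place of bromo on an aromatic carbon. Among the compounds with values here, no measured pair shows this change. No step beyond the scatter is expected in this assay and no direction can be favoured. The estimated step is a 1.1-fold lower number from compound 2 to compound 3 (0.02 log units; within the scatter) at this stage. For compound 3 the expected value is 12000 nM with an estimated range of 6500 nM to 22000 nM for now.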

Compound 3, half-maximal inhibitory concentration: 13400 nM
Compound 3: middle estimate off by 1.1-fold (0.05 log units), on the low side; the measured number falls inside the stated range.
By their numbers in this assay, from the lowest: compounds 1, 2 and 3 (each within the scatter of the next).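

In this assay, within the data shown here, cyano in place of bromo on an aromatic carbon, para to a group of 4 heavy atoms, gives a 1.1-fold higher number from compound 2 to compound 3 (0.02 log units; within the scatter) and so forms the first single-place comparison. At this position, the two groups cannot be told apart in this assay. No measured evidence bears on this result. From the compounds shown here alone, an amine or a carboxylic acid at the same position remains open, as does any replacement of the selenocyanate group by a longer chain.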